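Swapping a benzoyl for a sulfonyl pyrazole on the shared core

The compounds below may be only part of what the source reports. "The series", "measured", "known", "first", "only" and "open" are said of these compounds alone.

Compound 2, `O=C(COc1ccc2c(=O)ccoc2c1)Nc1cccc(NC(=O)c2ccccc2)c1`: 16 nM
Compound 1, `COc1cc(OCC(=O)Nc2cccc(NC(=O)c3ccc(N(C)C)cc3)c2)ccc1C=O`: 306 nM

In an assay on isolated protein for inhibition of Rho-associated protein kinase 2 (Homo sapiens), read by scintillation counting, radiometric assay and 33P incorporation, with a stated time of 40 min, in the presence of a further agent that is not named here (a lower number here means a stronger inhibitor, a higher number a weaker inhibitor), compound 2 gives 16 nM, the lowest of the two numbers; the gap to compound 1 is well beyond the usual scatter. Compound 3, `Cn1ccc(S(=O)(=O)Nc2cccc(NC(=O)COc3ccc4c(=O)ccoc4c3)c2)n1`, has not yet been measured. It differs from compound 2 in one place: a group of 9 heavy atoms (4 carbon, 2 nitrogen, 2 oxygen, 1 sulfur; one five-membered aromatic ring with 2 hetero atoms) in place of a group of 8 heavy atoms (7 carbon, 1 oxygen; one six-membered aromatic ring of carbon only), on a nitrogen on an aromatic ring. Within the data shown here, no step of this kind has been measured here, so nothing measured points the way. A moderate weakening is expected, with the step of a 3.1-fold higher number from compound 2 to compound 3 (0.49 log units; beyond the scatter) taken as beyond the scatter. Compound 3 is expected to give 50 nM in this assay, within 12 nM to 250 nM.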

Compound 3, half-maximal inhibitory concentration: 1350 nM
The estimate for compound 3 lay 27-fold (1.43 log units) below the measured number, outside the stated range (above it).
By their numbers in this assay, from the lowest: compound 2; then compound 1; then compound 3.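

In this assay, putting the sulfonyl pyrazole group in place of benzoyl on the nitrogen gives an 84-fold higher number from compound 2 to compound 3 (1.93 log units; beyond the scatter), so what sits at this place matters greatly. Compounds 1 and 2 differ in more than one place, which makes this the first single change shown here. Nothing measured here explains the size of this step.

The linking group and the ring change together, so the compounds shown do not tell which one accounts for the step. A phenylsulfonyl group or a pyrazole carbonyl group on the same nitrogen would separate the two.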